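A few compounds are considered here, and "the series" means these few. Any claim that something is new, unique, unknown or untested is made for them only; others in the source may bear on it.

Three compounds share one core and differ only in the group carried on an amine nitrogen in a ring. Compound 1 `Nc1nc(N)c2cc(CSC(=S)N3CCN(C4CCCCC4)CC3)ccc2n1` bears a cyclohexyl there; in a functional assay on HT-29 cells (Homo sapiens) for antiproliferative activity, read by MTT assay, with a stated time of 72 h (on this read-out lower numbers stand for stronger inhibition and higher numbers for weaker inhibition), compound 1 gives 4050 nM, the highest of the three numbers, so the weakest inhibition among them. Compound 2 `COc1ccc(N2CCN(C(=S)SCc3ccc4nc(N)nc(N)c4c3)CC2)cc1` carries a 4-methoxyphenyl instead and in this assay compound 2 gives 1770 nM, a change of a 2.3-fold lower number from compound 1 to compound 2 (0.36 log units; beyond the scatter). Compound 3 `Nc1nc(N)c2cc(CSC(=S)N3CCN(c4ccc(Cl)c(Cl)c4)CC3)ccc2n1` carries a 3,4-dichlorophenyl and in this assay compound 3 gives 3480 nM, a change of a 1.2-fold lower number from compound 1 to compound 3 (0.07 log units; within the scatter), while between compound 2 and compound 3 the step is a 2.0-fold higher number from compound 2 to compound 3 (0.29 log units; within the scatter).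

Compound 4 `Nc1nc(N)c2cc(CSC(=S)N3CCN(c4ccc(F)cc4F)CC3)ccc2n1` has not been measured. Its difference from compound 1 is 2,4-difluorophenyl in place of cyclohexyl on an amine nitrogen in a ring: a six-membered non-aromatic ring of carbon only leaves and a six-membered aromatic ring of carbon only, bearing two fluorine atoms, enters at the same place. The two measured steps that swap cyclohexyl for an aromatic ring both point the same way, one modest and beyond the scatter, one within it. The expected step of a 1.4-fold lower number from compound 1 to compound 4 (0.15 log units; within the scatter) is therefore small and toward a lower number, possibly not beyond the scatter. Compound 4 is expected to give 2900 nM in this assay, with a likely range from 1500 nM to 5800 nM.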

Compound 4, half-maximal inhibitory concentration: 5020 nM
Beside the measured number, compound 4's estimate is 1.7-fold (0.24 log units) below it; measured number inside the range.
By their numbers in this assay, from the lowest: compounds 2, 3, 1 and 4 (each within the scatter of the next, the first and the last beyond it).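

In this assay, putting an aromatic ring on this nitrogen does not by itself go with a lower number: 2,4-difluorophenyl cannot be told apart from cyclohexyl (a 1.2-fold higher number from compound 1 to compound 4 (0.09 log units; within the scatter)) or from 3,4-dichlorophenyl (a 1.4-fold higher number from compound 3 to compound 4 (0.16 log units; within the scatter)). Only 4-methoxyphenyl separates from it (a 2.8-fold higher number from compound 2 to compound 4 (0.45 log units; beyond the scatter)), so the aromatic rings shown do not all behave alike and the groups they carry can matter at this position, although the step from compound 2 to compound 3 lies within the scatter and keeps that split from being clean. Nothing among the data shown gives a reason for this difference.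

All the groups shown on this nitrogen are cyclohexyl or a phenyl ring bearing methoxy, chlorine or fluorine, so it remains open what a plain phenyl, a pyridine ring or a benzyl group would give here. As far as these compounds go, it also remains open whether the lower number of compound 2 depends on the methoxy group itself or on where it stands, which a 3-methoxyphenyl or a 4-hydroxyphenyl group could help to separate.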